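Aminopiperidine for methylsulfonylpiperazine on the azetidine carbon

The source may hold more compounds than are shown below. What is called first, only, known or untested is meant among the compounds shown, and "the series" means these compounds.

Measured so far:
compound 1 `CS(=O)(=O)N1CCN(C2CN(CCC3(c4ccc(Cl)c(Cl)c4)CCC(=O)N(Cc4ccccc4)C3)C2)CC1` — 0.631 nM
compound 2 `CS(=O)(=O)N1CCN(C2CN(CCC3(c4ccc(Cl)c(Cl)c4)CCC(=O)N(CC4CC4)C3)C2)CC1` — 3.16 nM

In an assay on isolated protein (artery, Oryctolagus cuniculus) with Substance-P receptor (Homo sapiens) as the target (a higher number here means weaker binding, a lower number tighter binding), compound 1 gives 0.631 nM and compound 2 gives 3.16 nM. Within the data shown here, the one measured step, a 5.0-fold higher number from compound 1 to compound 2 (0.70 log units; beyond the scatter), is the only structural comparison available. Compound 2 stands with the higher of the two numbers, with compound 1 as its nearest neighbour.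

Compound 3 `NC1CCN(C2CN(CCC3(c4ccc(Cl)c(Cl)c4)CCC(=O)N(CC4CC4)C3)C2)CC1` is not yet measured in this assay. It differs from compound 2 by 4-aminopiperidin-1-yl in place of 4-(methylsulfonyl)piperazin-1-yl on a saturated ring carbon. Among the measured compounds shown here, no measured pair probes a change at this position; the single step concerns the group on the amide nitrogen and says nothing about the exchange made here. The size and direction of the effect are therefore open, and the working assumption is a step no larger than the scatter, with wide margins. Compound 3 is expected near 3.5 nM, within 0.8 nM to 16 nM. The expected step to compound 3 is a 1.1-fold higher number from compound 2 to compound 3 (0.04 log units; within the scatter).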

Compound 3, dissociation constant: 2 nM
Compound 3: the middle estimate sits 1.8-fold (0.24 log units) above what was measured; measured number inside the range.
By their numbers in this assay, from the lowest: compound 1; then compounds 3 and 2 (each within the scatter of the next).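

At the saturated ring carbon of the four-membered ring, in this assay, 4-aminopiperidin-1-yl in place of 4-(methylsulfonyl)piperazin-1-yl gives a 1.6-fold lower number from compound 2 to compound 3 (0.20 log units; within the scatter), so this measurement does not separate the two compounds. The position therefore accepts a substantial change with no step beyond the scatter: 7 heavy atoms enter, fewer than leave, the sulfur and both oxygens leave, and 1 hydrogen-bond donor enters where there were 0. Nothing available accounts for this result.

The compounds shown leave open whether the primary amine itself matters, which a 4-hydroxypiperidin-1-yl or 4-acetamidopiperidin-1-yl group at the same carbon would test. Also open, from the compounds shown here alone, is whether 4-aminopiperidin-1-yl behaves the same way with a benzyl group on the amide nitrogen, as in compound 1, since compound 3 carries cyclopropylmethyl there.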